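A few compounds are considered here, and "the series" means these few. Any claim that something is new, unique, unknown or untested is made for them only; others in the source may bear on it.

Notes on the series. Compound 3 `CC(=O)OC[C@H]1O[C@@H](CC(=O)/C=C2\C(=O)N(Cc3ccccc3)c3ccccc32)[C@H](OC(C)=O)[C@@H](OC(C)=O)[C@@H]1OC(C)=O` stands at 71200 nM in an ADME assay on Vero cells (Chlorocebus sabaeus) for cytotoxicity, read by resazurin assay, with a stated time of 72 h; a lower number here means that less compound is tolerated, a higher number that more compound is tolerated. Compound 2 `CCCN1C(=O)/C(=C\C(=O)C[C@@H]2O[C@H](COC(C)=O)[C@@H](OC(C)=O)[C@H](OC(C)=O)[C@H]2OC(C)=O)c2ccccc21` gives 125000 nM in this assay; the step of a 1.8-fold lower number from compound 2 to compound 3 (0.24 log units; within the scatter) lies within the scatter, so the two numbers shown so far cannot be told apart. Compound 1 `CC(=O)OC[C@H]1O[C@@H](CC(=O)CC2(O)C(=O)N(Cc3cccc(C)c3)c3ccc(Cl)cc32)[C@H](OC(C)=O)[C@@H](OC(C)=O)[C@@H]1OC(C)=O` has "not determined" (no result reported) in this assay, so no number is reported for it. Compound 4 `CC(=O)OC[C@H]1O[C@@H](CC(=O)/C=C2\C(=O)N(Cc3ccc(F)cc3)c3ccccc32)[C@H](OC(C)=O)[C@@H](OC(C)=O)[C@@H]1OC(C)=O` differs from compound 3 by fluoro in place of hydrogen on an aromatic carbon, on an aromatic carbon of a six-membered aromatic ring of carbon only, para to a large group. For the measured compounds named here, no measured step exchanges a hydrogen for a fluoro on such a ring; the only measured step, a 1.8-fold lower number from compound 2 to compound 3 (0.24 log units; within the scatter), changes the group on the saturated chain carbon bound to the amide-type nitrogen and stays within the scatter, so it bears only loosely on the present change. With nothing in the measured steps pointing to a move beyond the scatter, the step of a 1.0-fold lower number from compound 3 to compound 4 (0.01 log units; within the scatter) is expected to be none beyond the scatter. Compound 4 is therefore estimated at 70000 nM in this assay, within a range from 30000 nM to 160000 nM.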

Compound 4, half-maximal cytotoxic concentration: 119000 nM
Estimate against measurement, compound 4: 1.7-fold (0.23 log units) below, and the stated range covers the measured number.
By their numbers in this assay, from the lowest: compounds 3, 4 and 2 (each within the scatter of the next).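

In this assay, for the compounds shown here, fluoro in place of hydrogen on an aromatic carbon of a six-membered aromatic ring of carbon only, para to a large group, gives the first reading at this position: a 1.7-fold higher number from compound 3 to compound 4 (0.22 log units; within the scatter), so the exchange has no effect that can be told from the scatter. The wider exchange of 4-fluorophenyl in place of ethyl gives a 1.1-fold lower number from compound 2 to compound 4 (0.02 log units; within the scatter), which leaves compound 2, compound 3 and compound 4 indistinguishable in this measure. No measured information bears on the reason for this result.

Only hydrogen and fluoro are shown at this position, so the outcome with an amine, a carboxylic acid or a methoxy group there remains open. With no number for compound 1, the chloro and methyl groups it carries also remain unread.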